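A Third Benzyl Variant on a Shared Core

The compounds below may be only part of what the source reports. "The series", "measured", "known", "first", "only" and "open" are said of these compounds alone.

Measured so far:
compound 1 `OC[C@H]1O[C@@H](n2cnc3c(NCc4ccc(F)cc4)ncnc32)[C@H](O)[C@@H]1O` — 1200 nM
compound 2 `OC[C@H]1O[C@@H](n2cnc3c(NCc4ccccc4Cl)ncnc32)[C@H](O)[C@@H]1O` — 1600 nM

In a functional assay on HL-60 cells (Homo sapiens) for antiproliferative activity, with a stated time of 72 h (a higher number here means a weaker inhibitor, a lower number a stronger inhibitor), compound 1 gives 1200 nM. Compound 2 gives 1600 nM. The change between them, 2-chlorophenyl in place of 4-fluorophenyl on a saturated chain carbon bound to a nitrogen on an aromatic ring, produced a 1.3-fold higher number from compound 1 to compound 2 (0.12 log units; within the scatter). Within the data shown here, compound 2 has the higher of the two numbers, but its only neighbour, compound 1, lies within the scatter, so no ranking can be read.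

Compound 3 `Cc1cccc(CNc2ncnc3c2ncn3[C@@H]2O[C@H](CO)[C@@H](O)[C@H]2O)c1` differs from compound 2 in one place: 3-methylphenyl in place of 2-chlorophenyl on a saturated chain carbon bound to a nitrogen on an aromatic ring. Among the measured compounds shown here, the only measured step that bears on this, swapping one substituted phenyl for another at the same position, barely moved the number, as a 1.3-fold higher number from compound 1 to compound 2 (0.12 log units; within the scatter) shows. A step within the scatter is therefore expected for compound 3, a 1.1-fold lower number from compound 2 to compound 3 (0.03 log units; within the scatter), in no firm direction. Compound 3 is estimated at 1500 nM in this assay, between 600 nM and 4000 nM.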

Compound 3, half-maximal inhibitory concentration: 6400 nM
Compound 3: the middle estimate sits 4.3-fold (0.63 log units) below what was measured, outside the stated range (above it).
By their numbers in this assay, from the lowest: compounds 1 and 2 (each within the scatter of the next); then compound 3.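

In this assay the choice of substituted phenyl on a saturated chain carbon bound to a nitrogen on an aromatic ring does matter: 3-methylphenyl brings a 4.0-fold higher number from compound 2 to compound 3 (0.60 log units; beyond the scatter) and a 5.3-fold higher number from compound 1 to compound 3 (0.73 log units; beyond the scatter). The earlier step within the scatter therefore did not mean that any substituted phenyl behaves alike here, since 2-chlorophenyl and 4-fluorophenyl stay together while 3-methylphenyl stands apart. Nothing at hand explains why this change weakens the compound.

The compounds shown leave open whether the methyl group itself or its place on the ring sets compound 3 apart. Also open, from the compounds shown here alone, is how this assay would read for an unsubstituted phenyl, a methoxy group on the ring, or a longer chain carrying the ring.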